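Swapping the Acid for an Alcohol on an Acrylamide

The source may hold more compounds than are shown below. What is called first, only, known or untested is meant among the compounds shown, and "the series" means these compounds.

Compound 1 `C=CC(=O)Nc1ccc(Cn2nc(-c3ccc(Oc4ccccc4)cc3)cc2C(=O)O)cc1` carries an acrylamide and a carboxy group on the shared core. In a functional assay on Z-138 cells (Homo sapiens) for inhibition, read by luminescence and CellTiter-Glo, with a stated time of 72 h (a lower number here means a stronger inhibitor, a higher number a weaker inhibitor), compound 1 gives > 60000 nM, which is a limit of the assay rather than a number. It sits at the limit of > 60000 nM in this assay, at which 2 of the 3 values shown sit, together with compound 2 `C/C=C/C(=O)Nc1ccc(Cn2nc(-c3ccc(Oc4ccccc4)cc3)cc2C(=O)OCC)cc1`. In this assay compound 2 gives > 60000 nM, again only a limit. Compound 3 `O=C(CCl)Nc1ccc(Cn2nc(-c3ccc(Oc4ccccc4)cc3)cc2C(=O)O)cc1`, with chloromethyl in place of vinyl on the carbonyl carbon, gives 1500 nM in this assay, and the step of an at least 40-fold lower number from compound 1 to compound 3 (1.60 log units; beyond the scatter) is large. Compound 4 `C=CC(=O)Nc1ccc(Cn2nc(-c3ccc(Oc4ccccc4)cc3)cc2CO)cc1` differs from compound 1 by hydroxymethyl in place of carboxy on an aromatic carbon. No measured step touches that change, and the carboxy-bearing compounds shown give only limits, so the direction is uncertain. Compound 4 is expected to give around 20000 nM (range 2000 nM to 60000 nM), a step of an at least 3.0-fold lower number from compound 1 to compound 4 (0.47 log units; beyond the scatter) that is an estimate only.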

Compound 4, half-maximal inhibitory concentration: 6800 nM
Beside the measured number, compound 4's estimate is 2.9-fold (0.47 log units) above it; the measured number falls inside the stated range.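

Until now, only the group on the carbonyl carbon had been seen to move the number. In this assay, hydroxymethyl in place of carboxy gives an at least 8.8-fold lower number from compound 1 to compound 4 (0.94 log units; beyond the scatter), so the aromatic carbon bearing this group matters too, even with the acrylamide unchanged. The true size of this step stays open-ended because compound 1 has only a limit: the limit of > 60000 nM in this assay, at which 2 of the 4 values shown sit.

The compounds shown leave open whether an amine or a plain methyl group at this position would do the same. They also leave open whether hydroxymethyl would lower the number for compound 3, with its chloromethyl group.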